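Changing the side chain on compound 2's aromatic nitrogen

A few compounds are considered here, and "the series" means these few. Any claim that something is new, unique, unknown or untested is made for them only; others in the source may bear on it.

All four compounds share one core; compound 1 has the structure `COc1nc(Cl)nc2c1ncn2[C@H]1C[C@H](N=[N+]=[N-])[C@@H](CO)O1` and compound 3 the structure `CN(C)c1nc(Cl)nc2c1ncn2[C@H]1C[C@H](N=[N+]=[N-])[C@@H](CO)O1`, which carries dimethylamino in place of methoxy on an aromatic carbon. In an ADME assay on CCRF-CEM cells (Homo sapiens) for cytotoxicity, with a stated time of 5 days (on this read-out higher numbers stand for weaker inhibition and lower numbers for stronger inhibition), compound 1 gives > 100000 nM, a limit of the assay rather than a number. Compound 3 gives > 100000 nM, again a limit. The one-place step that the two limits leave unreadable from compound 1 to compound 3 therefore cannot be read. Compound 2, with the structure `C#CCNc1nc(N)nc2c1ncn2[C@H]1C[C@H](N=[N+]=[N-])[C@@H](CO)O1`, gives > 100000 nM in this assay, also a limit. All of the numbers shown thus sit at the same place, summarized as the limit of > 100000 nM in this assay, at which 3 of the 3 values shown sit.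

Compound 4 has the structure `CC(CO)Nc1nc(N)nc2c1ncn2[C@H]1C[C@H](N=[N+]=[N-])[C@@H](CO)O1`. It differs from compound 2 by 1-(hydroxymethyl)ethyl in place of propargyl on a nitrogen on an aromatic ring. No measured step touches this kind of change, and the one step that is shown is unreadable, so there is no footing for expecting a shift in either direction beyond the scatter. Compound 4 is therefore expected to give about 100000 nM in this assay, with a range from 50000 nM to 300000 nM. The expected step is a number no higher from compound 2 to compound 4 (the limit leaves the size open), meaning essentially no change, and the most likely outcome is that compound 4 is also reported only as a limit.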

Compound 4, half-maximal inhibitory concentration: > 100000 nM
Compound 4 ended at the assay's limit (the forecaster's own chance of this, stated with the estimate: 80%); the middle value lies on the limit itself.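

Compound 2 and compound 4 both end at a limit of this assay rather than at a number, so the step between them cannot be read. The compounds shown leave open whether any of these changes on the shared core alters cytotoxicity at all, since every result sits at one place: the limit of > 100000 nM in this assay, at which 4 of the 4 values shown sit.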